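The compounds below may be only part of what the source reports. "The series", "measured", "known", "first", "only" and "open" are said of these compounds alone.

Compound 3 `O=C(C1CCCC1)N1CCc2nc(C#Cc3ccccc3)sc2C1` is one of three compounds that share a core and differ only in the group on the ring amine nitrogen. In an assay on HEK293 cells for positive allosteric modulation of metabotropic glutamate receptor 5 (Homo sapiens), read by FLIPR, with a stated time of 1 h (a lower number here means that less compound is needed, a higher number that more compound is needed for the effect), compound 3 gives 19 nM, the second highest of the three numbers. Its nearest neighbour is compound 1 `CN1CCc2nc(C#Cc3ccccc3)sc2C1`, which gives 34 nM; the two lie within the scatter of each other, as a 1.8-fold lower number from compound 1 to compound 3 (0.25 log units; within the scatter) shows. The furthest is compound 2 `O=C(C1CC12CCC2)N1CCc2nc(C#Cc3ccccc3)sc2C1`, which gives 3.9 nM; the step of a 4.9-fold higher number from compound 2 to compound 3 (0.69 log units; beyond the scatter) is beyond the scatter, as is an 8.7-fold lower number from compound 1 to compound 2 (0.94 log units; beyond the scatter).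

Compound 4 `O=C(C1CCOCC1)N1CCc2nc(C#Cc3ccccc3)sc2C1` carries the change (oxan-4-yl in place of cyclopentyl on a carbonyl carbon). For the measured compounds named here, the only measured step at the carbonyl carbon, a 4.9-fold higher number from compound 2 to compound 3 (0.69 log units; beyond the scatter), swapped one ring system for another and was modest; the other two steps replaced methyl with an acyl group. Going by the values given here, none of them involves a ring bearing an oxygen, so no precedent speaks directly to this change. A step of no more than the scatter is therefore expected, a 1.3-fold higher number from compound 3 to compound 4 (0.12 log units; within the scatter), and compound 4 is estimated at 25 nM, between 8 nM and 80 nM.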

Compound 4, half-maximal effective concentration: 290 nM
The estimate for compound 4 lay 12-fold (1.06 log units) below the measured number, and the stated range ends below it.
By their numbers in this assay, from the lowest: compound 2; then compounds 3 and 1 (each within the scatter of the next); then compound 4.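

In this assay, for the compounds shown here, the group on the carbonyl carbon turns out to matter far more than the earlier compounds suggested: oxan-4-yl in place of cyclopentyl brings a large step (a 15-fold higher number from compound 3 to compound 4 (1.18 log units; beyond the scatter)), from a swap that enters a six-membered ring with a ring oxygen and a hydrogen-bond acceptor. The gap to the best acyl group shown is larger still (a 74-fold higher number from compound 2 to compound 4 (1.87 log units; beyond the scatter)). An acyl group in place of methyl also no longer leaves the number level or lower, for this one goes the other way (an 8.5-fold higher number from compound 1 to compound 4 (0.93 log units; beyond the scatter)).

The compounds shown cannot separate the ring oxygen from the change in ring size, and a cyclohexyl group on this carbonyl carbon would tell the two apart. No evidence at hand gives a cause for these steps.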